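Replacing the oxazole with an ethylsulfonamide on the shared core

The source may report more compounds than this note shows. Statements on the series, on what has been measured and on what is new or still open speak of the compounds shown alone.

Measured so far in a functional assay on CHO cells for agonist activity at Alpha-1A adrenergic receptor (Homo sapiens), read by FLIPR and calcium flux; a lower number here means that less compound is needed, a higher number that more compound is needed for the effect:
compound 1, `c1cc(-c2ccn[nH]2)c2c(c1)C(c1ncc[nH]1)CC2`, 52 nM
compound 2, `c1cc(-c2ncco2)c2c(c1)C(c1ncc[nH]1)CC2`, 170 nM

Compound 2 holds the higher of the two numbers; compound 1 sits a modest step away, the step of a 3.3-fold higher number from compound 1 to compound 2 (0.51 log units; beyond the scatter) lying beyond the scatter. Compound 3, `CCS(=O)(=O)Nc1cccc2c1CCC2c1ncc[nH]1`, is not yet measured in this assay. It differs from compound 2 as follows: (ethylsulfonyl)amino in place of 1,3-oxazol-2-yl on an aromatic carbon. The group that leaves is a five-membered aromatic ring; the group that enters is a non-cyclic (ethylsulfonyl)amino bearing one hydrogen-bond donor, placed on the aromatic carbon of the six-membered ring of carbon only, ortho to a fused ring and meta to a fused ring.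

Going by the values given here, only one measured step exists, and it compares two aromatic rings at this same position, so it bears on compound 3 only loosely. Its size suggests that changes at this site move the number by modest amounts. Among the compounds with values here, no step involving a sulfonamide is available, so the direction is open. For compound 3 the expected step from compound 2 is a 1.1-fold lower number from compound 2 to compound 3 (0.05 log units; within the scatter), close to no change. Compound 3 is estimated at 150 nM, with a range from 40 nM to 600 nM.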

Compound 3, half-maximal effective concentration: 32 nM
The estimate for compound 3 lay 4.7-fold (0.67 log units) above the measured number; measured number outside the range, below it.
By their numbers in this assay, from the lowest: compounds 3 and 1 (each within the scatter of the next); then compound 2.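

In this assay this aromatic carbon does not depend on a five-membered aromatic ring: the non-cyclic (ethylsulfonyl)amino group in place of 1,3-oxazol-2-yl gives a 5.3-fold lower number from compound 2 to compound 3 (0.73 log units; beyond the scatter) and so reverses the direction of the earlier step, a 3.3-fold higher number from compound 1 to compound 2 (0.51 log units; beyond the scatter) in the ring-for-ring change. Set against 1H-pyrazol-5-yl, the same group gives a 1.6-fold lower number from compound 1 to compound 3 (0.21 log units; within the scatter) and stays within the scatter, so compound 1 and compound 3 cannot be ordered, and a ring and a non-cyclic group both fit the lower end of the values seen so far. The oxazole of compound 2 is counted with no hydrogen-bond donors and the (ethylsulfonyl)amino group of compound 3 with 1, but nothing at hand ties that count to the step, and no supporting data bear on why the number moves.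

From the compounds shown here alone, how a methyl or a propyl chain in place of the ethyl on the sulfonyl would read remains open, and so does whether the sulfonyl is needed at all. A plain amine or a carboxylic acid on this aromatic carbon would test that second question, and the compounds shown give no reading for either group.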